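The source may hold more compounds than are shown below. What is called first, only, known or untested is meant among the compounds shown, and "the series" means these compounds.

Compound 3, with the structure `CC1(C)CCC(NC/C=C/CN(C[C@H]2Cc3ccccc3CN2)[C@H]2CCCc3cccnc32)CC1`, gives 64.6 nM in a functional assay on cells for antagonist activity at C-X-C chemokine receptor type 4 (Homo sapiens), read by fluorescence and calcium flux, with stated times of 25 min and 90 s; a lower number here means a stronger inhibitor, a higher number a weaker inhibitor. Its number sits close to those of the other two compounds measured: compound 2, with the structure `CC(C)(CN)CCN(C[C@H]1Cc2ccccc2CN1)[C@H]1CCCc2cccnc21`, gives 69 nM in this assay, and compound 1, with the structure `NCc1ccccc1CN(C[C@H]1Cc2ccccc2CN1)[C@H]1CCCc2cccnc21`, gives 50.8 nM; all three lie within the scatter of one another, so no order among them can be read.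

Compound 4, with the structure `C(=C/CN(C[C@H]1Cc2ccccc2CN1)[C@H]1CCCc2cccnc21)\CNCc1cccnc1`, differs from compound 3 at the far end of the chain: (pyridin-3-yl)methyl in place of 4,4-dimethylcyclohexyl on an amine nitrogen. Going by the values given here, the only measured step that touches a comparable position is the one between the first two compounds, where a 2-(aminomethyl)-2-methylpropyl group took the place of a 2-(aminomethyl)phenyl group on the chain carbon bound to the amine nitrogen, giving a 1.4-fold higher number from compound 1 to compound 2 (0.13 log units; within the scatter). That single step stayed within the scatter, and the distal portion of the chain has so far tolerated both aliphatic and aromatic groups without a shift beyond it. On that basis compound 4 is expected to show no step beyond the scatter, a 1.0-fold higher number from compound 3 to compound 4 (0.00 log units; within the scatter). The estimate for compound 4 in this assay is 65 nM, with a range from 30 nM to 140 nM.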

Compound 4, half-maximal inhibitory concentration in the C-X-C chemokine receptor type 4 assay: 92.8 nM
The estimate for compound 4 lay 1.4-fold (0.15 log units) below the measured number, within the range that was stated.
By their numbers in the C-X-C chemokine receptor type 4 assay, from the lowest: compounds 1, 3, 2 and 4 (each within the scatter of the next).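

With (pyridin-3-yl)methyl in place of 4,4-dimethylcyclohexyl on the amine nitrogen, the C-X-C chemokine receptor type 4 assay shows a 1.4-fold higher number from compound 3 to compound 4 (0.16 log units; within the scatter), so this position accepts an aromatic ring with a hetero atom as well as a non-aromatic ring of carbon only. The larger exchanges at the chain read the same way, with a 1.3-fold higher number from compound 2 to compound 4 (0.13 log units; within the scatter) and a 1.8-fold higher number from compound 1 to compound 4 (0.26 log units; within the scatter). Across these four compounds, the groups at the end of the chain have varied from one with no ring to aromatic and non-aromatic rings with no step beyond the scatter, and no order can be read among them.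

Whether a carboxylic acid, an amide or a longer chain on this amine nitrogen would move the number beyond the scatter stays open, and no evidence bears on why the numbers stay so close. In a physicochemical assay for permeability, using PAMPA, with a stated time of 4 h, at pH 5.5, tested at 100 uM (a higher number here means that the compound crosses the layer faster, a lower number that the compound crosses the layer more slowly), compound 3 gives "not determined" (no result reported) and compound 4 gives "not determined" (no result reported), so no step can be read there.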